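A few compounds are considered here, and "the series" means these few. Any claim that something is new, unique, unknown or untested is made for them only; others in the source may bear on it.

Working notes on the series. Compound 1 `COc1cc(-c2nn(-c3cccc(NC(=O)c4cccc(C(F)(F)F)c4)c3)cc2-c2ccncc2)ccc1Cl` in a functional assay on IGROV-1 cells (Homo sapiens) for inhibition, read by sulforhodamine B assay, with a stated time of 48 h (a higher number here means a weaker inhibitor of growth, a lower number a stronger inhibitor of growth), reaches only a limit, > 50000 nM. Compound 2 `COc1cc(-c2nn(-c3cccc(NC(=O)Nc4cccc(C(F)(F)F)c4)c3)cc2-c2ccncc2)ccc1Cl` gives 3110 nM in this assay, the step being an at least 16-fold lower number from compound 1 to compound 2 (1.20 log units; beyond the scatter). Compound 3 `COc1cc(-c2nn(-c3cccc(NC(=O)Nc4ccc(Cl)c(C(F)(F)F)c4)c3)cc2-c2ccncc2)ccc1Cl` gives 4220 nM in this assay, with an at least 11-fold lower number from compound 1 to compound 3 (1.07 log units; beyond the scatter) and a 1.4-fold higher number from compound 2 to compound 3 (0.13 log units; within the scatter); compound 3 and compound 2 thus sit within the scatter of one another. The value of compound 1 is a limit, per (the limit of > 50000 nM in this assay, at which 1 of the 3 values shown sits).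

Compound 4 `O=C(Nc1cccc(-n2cc(-c3ccncc3)c(-c3ccc(Cl)c(O)c3)n2)c1)Nc1ccc(Cl)c(C(F)(F)F)c1` differs from compound 3 by hydrogen in place of methyl on an oxygen on an aromatic ring. Every measured step concerns the group on the carbonyl carbon, so none bears on this methoxy-to-hydroxy change; no step beyond the scatter is expected in this assay. Compound 4 is therefore estimated at 4500 nM, between 1500 nM and 15000 nM. The expected step is a 1.1-fold higher number from compound 3 to compound 4 (0.03 log units; within the scatter).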

Compound 4, concentration for total growth inhibition: 2220 nM
Compound 4: the middle estimate sits 2.0-fold (0.31 log units) above what was measured; measured number inside the range.
By their numbers in this assay, from the lowest: compounds 4, 2 and 3 (each within the scatter of the next). At a limit, above all of these: compound 1.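

In this assay, among the compounds shown here, the methoxy-to-hydroxy change gives a 1.9-fold lower number from compound 3 to compound 4 (0.28 log units; within the scatter), the first step read away from the carbonyl carbon. On this aromatic ring, methoxy and hydroxy are therefore not told apart by this read-out, and the methyl on the oxygen is not needed to keep the number in the range of compound 2 and compound 3. No measurement shown gives a cause for this step.

On these data alone, whether an ethoxy group, a longer ether chain or an amine at this place would hold the number in that range stays open. Also open, as far as these compounds go, is whether the same change would read alike with the urea-free amide of compound 1, whose value is only a limit.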